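The source may report more compounds than this note shows. Statements on the series, on what has been measured and on what is new or still open speak of the compounds shown alone.

Of the compounds shown here, three built on a shared core have been measured in an assay on Sf21 cells for inhibition of high affinity nerve growth factor receptor (Homo sapiens), read by HTRF, with a stated time of 30 min, in the presence of a further agent that is not named here; on this read-out higher numbers stand for weaker inhibition and lower numbers for stronger inhibition. Compound 1 `CC1(C)c2[nH]nc(NC(=O)c3ccccc3)c2CN1Cc1ccccc1` gives 1240 nM. Compound 2 `CC1(C)c2[nH]nc(NC(=O)c3ccccc3)c2CN1Cc1cc(C(F)(F)F)cc(C(F)(F)F)c1` gives 16400 nM, the highest number of the three. Compound 3 `CC1(C)c2[nH]nc(NC(=O)c3ccc4ncccc4c3)c2CN1Cc1cc(F)cc(F)c1` gives 180 nM, the lowest number; its gap to compound 1 and its wider gap to compound 2 both lie beyond the usual scatter of repeated measurements, so compound 3 is the strongest inhibitor of the three.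

Compound 4 `CN(C)c1ccc(C(=O)Nc2n[nH]c3c2CN(Cc2cc(F)cc(F)c2)C3(C)C)cc1` has not yet been measured. It differs from compound 3 in one place: 4-(dimethylamino)phenyl in place of quinolin-6-yl on a carbonyl carbon. For the measured compounds named here, no pair of measured compounds shows a change of this kind, so the size of the step rests on judgement rather than on a precedent. With compound 3 at 180 nM as the starting point, the step from compound 3 to compound 4 is expected to be a modest weakening, a 2.8-fold higher number from compound 3 to compound 4 (0.44 log units; beyond the scatter), though a result within the scatter would not be surprising. Compound 4 is therefore estimated at 500 nM, with a likely range from 150 nM to 1600 nM.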

Compound 4, half-maximal inhibitory concentration: 96 nM
Estimate against measurement, compound 4: 5.2-fold (0.72 log units) above; measured number below the stated range.
By their numbers in this assay, from the lowest: compounds 4 and 3 (each within the scatter of the next); then compound 1; then compound 2.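

In this assay, putting 4-(dimethylamino)phenyl in place of quinolin-6-yl on the carbonyl carbon gives a 1.9-fold lower number from compound 3 to compound 4 (0.27 log units; within the scatter), so the two compounds cannot be told apart. This position therefore accepts a group with one aromatic ring of carbon only as well as one with two aromatic rings, and the nitrogen can sit in a ring or in a dimethylamino group without a change beyond the scatter, at least in this one pair. Nothing available here explains why these two different groups read alike.

Going by these compounds, it remains open whether the dimethylamino nitrogen matters at all, which a 4-methoxyphenyl or 4-ethylphenyl group in the same place could test. A larger amine, such as a 4-(morpholin-4-yl)phenyl group, would show how much more room this position allows.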